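Swapping cyclopropyl for 4-methoxyphenyl on the ring nitrogen

The source may hold more compounds than are shown below. What is called first, only, known or untested is meant among the compounds shown, and "the series" means these compounds.

Values in a functional assay on HeLa cells (Homo sapiens) for antiproliferative activity, read by MTT assay, with a stated time of 72 h (a higher number here means a weaker inhibitor, a lower number a stronger inhibitor), so far:
compound 1 `COc1ncc(-c2ccc3c(c2)NC(=O)CO3)cc1NS(=O)(=O)c1ccc(F)cc1` gives 7110 nM
compound 2 `COc1ncc(-c2ccc3c(c2)N(C2CC2)C(=O)CO3)cc1NS(=O)(=O)c1ccc(F)cc1` gives 6030 nM

Compound 2 cannot be separated from compound 1 on these numbers. For the measured compounds named here, the only measured step is a 1.2-fold lower number from compound 1 to compound 2 (0.07 log units; within the scatter) and it stays within the scatter.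

Compound 3 `COc1ccc(N2C(=O)COc3ccc(-c4cnc(OC)c(NS(=O)(=O)c5ccc(F)cc5)c4)cc32)cc1` is still unmeasured. It carries 4-methoxyphenyl in place of cyclopropyl on an amide-type nitrogen in a ring. Going by the values given here, the one step that bears on it changes the same nitrogen, and that step (a 1.2-fold lower number from compound 1 to compound 2 (0.07 log units; within the scatter)) gives no sign of sensitivity in this assay at this place. Among the compounds with values here, no aromatic group has yet been measured there, so the range stays wide and the direction open. The estimated step is a 1.1-fold lower number from compound 2 to compound 3 (0.04 log units; within the scatter) and no shift beyond the scatter is expected. Compound 3 is expected near 5500 nM (estimated range 2000 nM to 15000 nM).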

Compound 3, half-maximal inhibitory concentration: 1220 nM
Estimate against measurement, compound 3: 4.5-fold (0.65 log units) above, and the stated range ends above it.
By their numbers in this assay, from the lowest: compound 3; then compounds 2 and 1 (each within the scatter of the next).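

In this assay the amide-type nitrogen in the ring now proves responsive to its substituent: 4-methoxyphenyl in place of cyclopropyl gives a 4.9-fold lower number from compound 2 to compound 3 (0.69 log units; beyond the scatter) and 4-methoxyphenyl in place of hydrogen gives a 5.8-fold lower number from compound 1 to compound 3 (0.77 log units; beyond the scatter) on the same core. Hydrogen and cyclopropyl could not be separated at this place, so the first sensitivity appears only with the entry of 4-methoxyphenyl, which brings a six-membered aromatic ring and a methoxy oxygen in a single change, and the step cannot be divided between them. No measurement available here accounts for the shift.

Still open, on these data alone, is whether the aromatic ring alone carries the step, which unsubstituted phenyl would address. A benzyl group or a phenyl ring bearing an amine or a carboxylic acid also remains untested in the compounds shown here.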